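The source may report more compounds than this note shows. Statements on the series, on what has been measured and on what is new or still open speak of the compounds shown alone.

Measured compounds:
compound 1 `CCN(CC)S(=O)(=O)c1ccc(S(=O)(=O)N2CCC[C@@H](C(=O)N3CCC(OC)CC3)C2)cc1` gives 1420 nM
compound 2 `CC(C)S(=O)(=O)c1ccc(S(=O)(=O)N2CCC[C@@H](C(=O)N3CCC(F)(F)CC3)C2)cc1` gives 50 nM
compound 3 `CCN(CC)S(=O)(=O)c1ccc(S(=O)(=O)N2CCC[C@@H](C(=O)N[C@H]3CCOC3)C2)cc1` gives 5270 nM

All three were tested in a functional assay on BXPC-3 cells (Homo sapiens) for inhibition, read by MTT assay, with a stated time of 7 days; on this read-out higher numbers stand for weaker inhibition and lower numbers for stronger inhibition. Compound 2 stands at the lowest number of the three, with compound 1 nearest and compound 3 furthest, both gaps beyond the scatter. For the measured compounds named here, the only single-point step among the measured compounds, a 3.7-fold higher number from compound 1 to compound 3 (0.57 log units; beyond the scatter), lies at the carbonyl and does not touch the sulfonyl sulfur.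

Compound 4 `CC(C)NS(=O)(=O)c1ccc(S(=O)(=O)N2CCC[C@@H](C(=O)N3CCC(F)(F)CC3)C2)cc1` is not yet measured. It differs from compound 2 in one place: isopropylamino in place of isopropyl on a sulfonyl sulfur. Going by the values given here, no measured step bears on this change directly. Compounds 1 and 3 both carry a diethylamino group on the sulfonyl sulfur and both give much higher numbers than compound 2, but each also differs from compound 2 at the carbonyl, so their values cannot be read as the effect of the sulfonyl change alone.

Given that, a modest weakening is expected, a 3.0-fold higher number from compound 2 to compound 4 (0.48 log units; beyond the scatter), with wide uncertainty. Compound 4 is estimated at 150 nM, within a range of 40 nM to 600 nM.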

Compound 4, half-maximal inhibitory concentration: 470 nM
Compound 4: middle estimate off by 3.1-fold (0.50 log units), on the low side; measured number inside the range.
By their numbers in this assay, from the lowest: compound 2; then compound 4; then compound 1; then compound 3.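

In this assay, the position on the sulfonyl sulfur now has a measured step of its own: isopropylamino in place of isopropyl gives a 9.4-fold higher number from compound 2 to compound 4 (0.97 log units; beyond the scatter). For the compounds shown here, the only earlier single-place step lay at the carbonyl, so this is the first result to show that the sulfonyl sulfur substituent alone moves the number, with the group on the carbonyl held unchanged. The change adds a nitrogen and a hydrogen-bond donor to the isopropyl group, but no measurement shown here accounts for the weaker inhibition.

Going by these compounds, whether the step keeps its size with other groups on the carbonyl remains open, as compounds 1 and 3 differ from compound 4 in more than one place. Also open, on these data alone, is how a dimethylamino group, or a longer chain such as butyl, would fare on the sulfonyl sulfur.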